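A Second Methoxy on a Scaffold Without Measured Activity

The source may hold more compounds than are shown below. What is called first, only, known or untested is meant among the compounds shown, and "the series" means these compounds.

Compound 1 `COc1ccc2oc(/C=C/c3ccc(OC(F)(F)F)cc3)cc(=O)c2c1`: > 40000 nM
Compound 2 `COc1ccc2c(=O)cc(/C=C/c3ccc(OC(F)(F)F)cc3)oc2c1`: > 40000 nM

In a functional assay on A549 cells (Homo sapiens) for antiproliferative activity, read by MTT assay, with a stated time of 12 h (a higher number here means a weaker inhibitor, a lower number a stronger inhibitor), compound 1 gives only a limit, > 40000 nM. In this assay compound 2 also gives only a limit, > 40000 nM. For the measured compounds named here, compound 2 therefore stands at the limit of > 40000 nM in this assay, at which 2 of the 2 values shown sit, and no step between measured compounds can be drawn from these two values. Compound 3 `COc1cc(OC)c2c(=O)cc(/C=C/c3ccc(OC(F)(F)F)cc3)oc2c1` differs from compound 2 by methoxy in place of hydrogen on an aromatic carbon. With nothing measured to guide the step, it is expected to be a step that the limit leaves unreadable from compound 2 to compound 3, none beyond the scatter, in this assay. Compound 3 is accordingly estimated at 50000 nM, within a range of 15000 nM to 200000 nM, and most probably reported again only as a limit.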

Compound 3, half-maximal inhibitory concentration: 24200 nM
For compound 3 the middle estimate is 2.1-fold (0.32 log units) above the measured one; measured number inside the range.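

For the compounds shown here, this aromatic carbon, meta to a methoxy group, is the first place where a change gives a number instead of a limit in this assay: compound 3 reads 24200 nM. The change amounts to an at least 1.6-fold lower number from compound 2 to compound 3 (0.21 log units; that floor lies within the scatter), so it is not shown to exceed the scatter. Its true size cannot be read because compound 2 stands at a limit: the limit of > 40000 nM in this assay, at which 2 of the 3 values shown sit.

From the compounds shown here alone, whether a hydroxyl group or an amine on this carbon would give a lower number remains open. So does whether methoxy here would act alike on the core of compound 1.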